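Replacing the aryl group: compound 3 to compound 4

The source may report more compounds than this note shows. Statements on the series, on what has been measured and on what is new or still open speak of the compounds shown alone.

Measured in a functional assay on MDA-MB-231 cells (Homo sapiens) for inhibition, read by MTT assay, with a stated time of 72 h; a lower number here means a stronger inhibitor, a higher number a weaker inhibitor:
Compound 1 `CC(C)(C)n1cc2c(n1)C(=O)CC1(CCN(C(=O)c3cc(-c4ccccc4Cl)nc4ccccc34)CC1)O2` gives > 10000 nM, which is a limit of this assay and not a number.
Compound 2 `COc1ccc(-c2cc(C(=O)N3CCC4(CC3)CC(=O)c3nn(C(C)(C)C)cc3O4)c3ccccc3n2)cc1OC` gives 7130 nM.
Compound 3 `CC(C)(C)n1cc2c(n1)C(=O)CC1(CCN(C(=O)c3cc(-c4ccc(N)cc4)nc4ccccc34)CC1)O2` gives 4960 nM.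

Compound 3 holds the lowest of the two numbers shown. Its nearest neighbour is compound 2, and that gap, a 1.4-fold lower number from compound 2 to compound 3 (0.16 log units; within the scatter), lies within the scatter, so no order between compound 2 and compound 3 can be read. Going by these compounds, compound 1 contributes only (the limit of > 10000 nM in this assay, at which 1 of the 3 values shown sits), and the steps of an at least 1.4-fold lower number from compound 1 to compound 2 (0.14 log units; that floor lies within the scatter) and an at least 2.0-fold lower number from compound 1 to compound 3 (0.30 log units; that floor lies within the scatter) are therefore floors whose size is unknown beyond the scatter.

Compound 4 `CCOc1cc(C(=O)N2CCC3(CC2)CC(=O)c2nn(C(C)(C)C)cc2O3)c2ccccc2n1` differs from compound 3 in one place: ethoxy in place of 4-aminophenyl on an aromatic carbon. None of the three measured steps bears directly on this change; each of them exchanges one six-membered aromatic ring of carbon only for another, whereas here the ring is removed and a short chain enters. The three measured compounds spread their values over a narrow band, which gives no basis for a large shift in either direction. The expected outcome for compound 4 is 9000 nM in this assay, with a range from 2500 nM to 30000 nM. The step of a 1.8-fold higher number from compound 3 to compound 4 (0.26 log units; within the scatter) is thus estimated as modest, with a real chance that the assay reports only a limit.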

Compound 4, half-maximal inhibitory concentration: > 10000 nM
Compound 4 ended at the assay's limit (the forecaster's own chance of this, stated with the estimate: 40%); middle value at least 1.1-fold (0.04 log units) away from the limit.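

In this assay compound 4 gives > 10000 nM, which is a limit of the assay and not a number. Among the compounds shown here, this is the first group at this position without a ring, and the steps of an at least 2.0-fold higher number from compound 3 to compound 4 (0.30 log units; that floor lies within the scatter) and an at least 1.4-fold higher number from compound 2 to compound 4 (0.14 log units; that floor lies within the scatter) are floors only, so they do not establish that exchanging the aryl group for ethoxy costs anything beyond the scatter, though no readable number is obtained with ethoxy on this carbon next to the ring nitrogen. Readable numbers so far come only with 4-aminophenyl in compound 3 and 3,4-dimethoxyphenyl in compound 2, with 2-chlorophenyl in compound 1 going against any link between an aryl group and a readable number, and the step between compound 1 and compound 4 cannot be read, so the two can be neither ordered nor separated: the limit of > 10000 nM in this assay, at which 2 of the 4 values shown sit.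

Going by these compounds, how far compound 4 actually lies from compound 3 remains unknown, since only a floor is available for that step. Also open, on these data alone, is whether a longer alkoxy chain, an amine or a saturated ring such as piperidine on this carbon would give a number inside the range of the assay, and whether any such group would separate from compound 2 and compound 3 by more than the scatter.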